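A few compounds are considered here, and "the series" means these few. Any claim that something is new, unique, unknown or untested is made for them only; others in the source may bear on it.

The measured compounds:
compound 1 `O=C1c2c[n+]([O-])c3ccccc3c2C(=O)c2c1c1ccccc1n2CCCCN1CCNCC1`: in a functional assay on MDA-MB-231 cells (Homo sapiens) for cytotoxicity, read by MTT assay, with a stated time of 72 h (on this read-out higher numbers stand for weaker inhibition and lower numbers for stronger inhibition), compound 1 gives 3310 nM
compound 2 `CC1(C)O[C@@H](CO)[C@H](Cn2cc(Cn3c4c(c5ccccc53)C(=O)c3c[n+]([O-])c5ccccc5c3C4=O)nn2)O1`: compound 2 gives 680 nM
compound 3 `CC1(C)OC[C@@H](Cn2cc(Cn3c4c(c5ccccc53)C(=O)c3c[n+]([O-])c5ccccc5c3C4=O)nn2)O1`: compound 3 gives only a limit of the assay, > 1000 nM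

Compound 1 stands at the highest of the two numbers; the nearest number, that of compound 2, is lower by a gap beyond the usual scatter, and the third value is a limit (the limit of > 1000 nM in this assay, at which 1 of the 3 values shown sits). Compound 4 `CN1CCN(CCCCCn2c3c(c4ccccc42)C(=O)c2c[n+]([O-])c4ccccc4c2C3=O)CC1` differs from compound 1 in one place: (4-methylpiperazin-1-yl)methyl in place of piperazin-1-yl on a saturated chain carbon, four bonds along the chain from an aromatic nitrogen. Among the measured compounds shown here, the only measured step, an at least 1.4-fold higher number from compound 2 to compound 3 (0.16 log units; that floor lies within the scatter), concerns a change on a saturated chain carbon bound to an aromatic nitrogen in another part of the molecule and stays within the scatter; it does not bear on the exchange at the chain end seen in compound 4. For the measured compounds named here, with no measured step touching that end, no shift beyond the scatter is expected, so compound 4 is estimated at 3500 nM (range 1200 nM to 10000 nM), which means an expected step of a 1.1-fold higher number from compound 1 to compound 4 (0.02 log units; within the scatter).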

Compound 4, half-maximal inhibitory concentration: 2270 nM
Beside the measured number, compound 4's estimate is 1.5-fold (0.19 log units) above it, and the stated range covers the measured number.
By their numbers in this assay, from the lowest: compound 2; then compounds 4 and 1 (each within the scatter of the next).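

In this assay, the exchange at the chain end gives a 1.5-fold lower number from compound 1 to compound 4 (0.16 log units; within the scatter), so this first measured step at that position stays within the scatter. At this position, the numbers therefore do not separate piperazin-1-yl from (4-methylpiperazin-1-yl)methyl, although the entering group has 0 hydrogen-bond donors and the leaving group has 1. Nothing measured here bears on why the two numbers lie so close.

From the compounds shown here alone, the step also changes the chain and adds the methyl group together, so the contribution of each remains open. Going by these compounds, it is likewise open whether a different group at the chain end, such as morpholin-4-yl, a dimethylamino group or a carboxylic acid, would move the number beyond the scatter.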